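This account rests on a few compounds, and the source may have more. Where it says the series, first, only, none or still open, it means among the compounds named here.

Three ureas built on a two-carbon nitrogen ring bearing a nitrile have been measured in a functional assay on MCF7 cells (Homo sapiens) for inhibition; a lower number here means a stronger inhibitor, a higher number a weaker inhibitor. Compound 1 `N#CC1CN1C(=O)Nc1ccc(F)cc1` gives 1900 nM in this assay. Compound 2 `CCOC(=O)c1ccc(NC(=O)N2CC2C#N)cc1` gives 2300 nM, and compound 3 `N#CC1CN1C(=O)Nc1ccc(Cl)cc1Cl` gives 900 nM. Among these three numbers compound 2 has the highest, and its nearest neighbour is compound 1, which lies within the scatter of it, while compound 3 lies beyond the scatter below it.

The next compound, compound 4 `N#CC1CN1C(=O)Nc1ccc([N+](=O)[O-])cc1`, differs from compound 2 in one place: nitro in place of ethoxycarbonyl on an aromatic carbon. Among the compounds with values here, the only measured step that touches the same position is the one from compound 1 to compound 2, where ethoxycarbonyl replaced fluoro and the number moved a 1.2-fold higher number from compound 1 to compound 2 (0.08 log units; within the scatter). That change of group at this position thus left this assay essentially unmoved. Nothing measured shows how a nitro group behaves here, so the expectation rests on that single step alone. The step from compound 2 to compound 4 is therefore expected to be small, a 1.4-fold lower number from compound 2 to compound 4 (0.13 log units; within the scatter), with no clear direction beyond the scatter. Compound 4 is estimated to give 1700 nM in this assay, within a range from 600 nM to 4500 nM.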

Compound 4, half-maximal inhibitory concentration: 3000 nM
Estimate against measurement, compound 4: 1.8-fold (0.25 log units) below, and the stated range covers the measured number.
By their numbers in this assay, from the lowest: compound 3; then compounds 1, 2 and 4 (each within the scatter of the next).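

The exchange of ethoxycarbonyl for nitro gives a 1.3-fold higher number from compound 2 to compound 4 (0.12 log units; within the scatter), and the exchange of fluoro for nitro gives a 1.6-fold higher number from compound 1 to compound 4 (0.20 log units; within the scatter), both in this assay. Where the earlier compounds offered a single comparison at this aromatic carbon, para to a group of 8 heavy atoms, three groups can now be compared pairwise, and none of the three steps goes beyond the scatter, so fluoro, ethoxycarbonyl and nitro are not told apart here despite their different heavy-atom counts. No measurement is available that could explain this lack of separation.

It remains open whether a group of another kind at this position, such as an amine, a carboxylic acid or a longer chain, would also stay within the scatter of these compounds. Compound 3 differs from the other compounds in more than one place, so the separate contribution of each of its two chloro groups also remains unresolved.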